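Adding a Methoxy Group to Three Weakly Active Compounds

The source may hold more compounds than are shown below. What is called first, only, known or untested is meant among the compounds shown, and "the series" means these compounds.

Compound 1 `COc1cc(OC)cc(-n2cc(-c3ccc(OC)c(O)c3)nn2)c1`: in a functional assay on MDA-MB-231 cells (Homo sapiens) for cytotoxicity, read by MTT assay (on this read-out higher numbers stand for weaker inhibition and lower numbers for stronger inhibition), compound 1 gives only a limit, > 10000 nM.
Compound 2 `COc1ccc(-c2cn(-c3cc(OC)c(OC)c(OC)c3)nn2)cc1O`: in this assay compound 2 gives only a limit, > 10000 nM.
Compound 3 `COc1cc(OC)cc(-c2cn(-c3ccc(OC(F)(F)F)cc3)nn2)c1`: in this assay compound 3 gives only a limit, > 1000 nM.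

From compound 1 to compound 2 the change is methoxy in place of hydrogen on an aromatic carbon. The step it made, a step that the two limits leave unreadable from compound 1 to compound 2, cannot be read because both values sit at the limit of > 10000 nM in this assay, at which 2 of the 3 values shown sit. Compound 4 `COc1cc(-c2cn(-c3ccc(OC(F)(F)F)cc3)nn2)cc(OC)c1OC` is not yet measured; it differs from compound 3 by methoxy in place of hydrogen on an aromatic carbon, the same change. The difference between the cores of compound 1 and compound 3 is not broken down here. Compound 3 sits at the limit of > 1000 nM in this assay, at which 1 of the 3 values shown sits. The step from compound 3 to compound 4 in this assay is expected to be a step that the limit leaves unreadable from compound 3 to compound 4, resting on the unreadable earlier step that the two limits leave unreadable from compound 1 to compound 2. Compound 4 is expected to give 15000 nM, estimated between 2000 nM and 100000 nM.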

Compound 4, half-maximal inhibitory concentration: > 10000 nM
Compound 4 ended at the assay's limit; the forecaster's own chance of this, stated with the estimate: 80%; the middle value does not contradict the limit.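

Compound 3 and compound 4 each give only a limit, and the step between them cannot be read. The compounds shown leave open whether adding a methoxy group, on either core, changes the result at all in this assay.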